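Swapping the Bromophenyl Group for a Butyl Chain

This account rests on a few compounds, and the source may have more. Where it says the series, first, only, none or still open, it means among the compounds named here.

Of the compounds shown here, three built on one shared core have been tested in a functional assay on CFPAC-1 cells (Homo sapiens) for antiproliferative activity, read by MTT assay, with a stated time of 72 h; on this read-out higher numbers stand for weaker inhibition and lower numbers for stronger inhibition. Compound 1 `O=C1O[C@H]([C@@H](O)Cn2cc(-c3cc(F)cc(F)c3)nn2)C(OCc2ccccc2)=C1OCc1ccccc1` gives 62400 nM, and compound 2 `O=C1O[C@H]([C@@H](O)Cn2cc(CNS(=O)(=O)c3ccc(Cl)cc3F)nn2)C(OCc2ccccc2)=C1OCc1ccccc1` gives 58200 nM. Compound 3 `O=C1O[C@H]([C@@H](O)Cn2cc(-c3ccc(Br)cc3)nn2)C(OCc2ccccc2)=C1OCc1ccccc1` gives 5830 nM, the lowest of the three numbers and so the strongest inhibitor among them; its gap to compound 2, the nearest value, lies beyond the scatter, as does its gap to compound 1. Within the data shown here, the only measured single-point step, an 11-fold lower number from compound 1 to compound 3 (1.03 log units; beyond the scatter), shows that exchanging one group at this position can shift the number a great deal.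

Compound 4 `CCCCc1cn(C[C@H](O)[C@H]2OC(=O)C(OCc3ccccc3)=C2OCc2ccccc2)nn1` differs from compound 3 in one place: butyl in place of 4-bromophenyl on an aromatic carbon. Among the measured compounds shown here, no measured pair replaces an aromatic ring with a plain chain, so that step bears on this change only indirectly, and the bromophenyl-bearing compound 3 is the best of the three. A move back toward weaker inhibition is expected, with a step of a 4.3-fold higher number from compound 3 to compound 4 (0.63 log units; beyond the scatter). Compound 4 is therefore estimated at 25000 nM, within a range of 8000 nM to 80000 nM.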

Compound 4, half-maximal inhibitory concentration: 73200 nM
The estimate for compound 4 lay 2.9-fold (0.47 log units) below the measured number, and the stated range covers the measured number.
By their numbers in this assay, from the lowest: compound 3; then compounds 2, 1 and 4 (each within the scatter of the next).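

The butyl chain does not keep the level of the 4-bromophenyl group in this assay: the change gives a 13-fold higher number from compound 3 to compound 4 (1.10 log units; beyond the scatter), so this position on the shared core tolerates the exchange poorly. Having an aromatic ring here is not enough on its own, since the butyl compound matches the 3,5-difluorophenyl compound, with a 1.2-fold higher number from compound 1 to compound 4 (0.07 log units; within the scatter), and also matches the compound carrying the sulfonamide side chain, with a 1.3-fold higher number from compound 2 to compound 4 (0.10 log units; within the scatter), leaving compound 3 alone apart from the other three. Nothing measured here explains why the 4-bromophenyl group stands out.

On these data alone, it remains open whether the bromine or the ring beneath it matters more, which a plain phenyl or a 4-chlorophenyl group on the same carbon could separate. A longer chain such as octyl, or a butyl chain carrying an amine, could show whether any non-aromatic group can do better than butyl.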